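This account rests on a few compounds, and the source may have more. Where it says the series, first, only, none or still open, it means among the compounds named here.

Measured compounds on record:

compound 1, `CC(=O)OC[C@H]1O[C@@H](n2cc(CN3C(=O)/C(=C/c4ccccc4)c4ccccc43)nn2)[C@H](OC(C)=O)[C@@H](OC(C)=O)[C@@H]1OC(C)=O` — 37100 nM
compound 2, `CC(=O)OC[C@H]1O[C@@H](n2cc(CN3C(=O)/C(=C/c4ccc(N(C)C)cc4)c4ccccc43)nn2)[C@H](OC(C)=O)[C@@H](OC(C)=O)[C@@H]1OC(C)=O` — 26300 nM
compound 3, `CC(=O)OC[C@H]1O[C@@H](n2cc(CN3C(=O)/C(=C/c4ccco4)c4ccccc43)nn2)[C@H](OC(C)=O)[C@@H](OC(C)=O)[C@@H]1OC(C)=O` — 29900 nM

All three numbers come from a functional assay on HeLa cells (Homo sapiens) for cytotoxicity, read by sulforhodamine B assay, with a stated time of 48 h; on this read-out lower numbers stand for stronger inhibition and higher numbers for weaker inhibition. Compound 3 stands second highest of the three; its nearest neighbour is compound 2, reached by a 1.1-fold higher number from compound 2 to compound 3 (0.06 log units; within the scatter), and its furthest is compound 1, with a 1.2-fold lower number from compound 1 to compound 3 (0.09 log units; within the scatter). Both steps sit within the scatter, as does a 1.4-fold lower number from compound 1 to compound 2 (0.15 log units; within the scatter), so the three measured compounds cannot be ordered against one another on this read-out.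

Compound 4, `CCC/C=C1/C(=O)N(Cc2cn([C@@H]3O[C@H](COC(C)=O)[C@@H](OC(C)=O)[C@H](OC(C)=O)[C@H]3OC(C)=O)nn2)c2ccccc21`, is still to be measured. Its change from compound 3 is propyl in place of furan-2-yl on a double-bonded chain carbon bound to a double-bonded ring carbon. Among the compounds with values here, the steps that bear on this position are the two that also exchange the group on the double-bonded chain carbon bound to the double-bonded ring carbon: from compound 1 to compound 3 and from compound 2 to compound 3. Neither moved the number beyond the scatter, although both kept an aromatic ring in place; propyl brings no ring at all, which the measured set does not cover. On this footing no shift beyond the scatter is expected in this assay, and the step is estimated as a 1.1-fold higher number from compound 3 to compound 4 (0.03 log units; within the scatter). Compound 4 is therefore expected near 32000 nM, with a range from 12000 nM to 85000 nM.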

Compound 4, half-maximal inhibitory concentration: > 100000 nM
Compound 4 was reported as a limit; the forecaster's own chance of this, stated with the estimate: 15%; middle value at least 3.1-fold (0.49 log units) away from the limit.
By their numbers in this assay, from the lowest: compounds 2, 3 and 1 (each within the scatter of the next). At a limit, above all of these: compound 4.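

Compound 4 is reported only as a limit in this assay: the limit of > 100000 nM in this assay, at which 1 of the 4 values shown sits. The position is therefore not indifferent to every exchange: phenyl, 4-(dimethylamino)phenyl and furan-2-yl lie within the scatter of one another, whereas propyl, which has no ring, gives an at least 3.3-fold higher number from compound 3 to compound 4 (0.52 log units; beyond the scatter) and an at least 3.8-fold higher number from compound 2 to compound 4 (0.58 log units; beyond the scatter) and an at least 2.6-fold higher number from compound 1 to compound 4 (0.43 log units; beyond the scatter) on the same read-out. All three steps lie beyond the scatter, but each gives only a lower bound, so the first sign of sensitivity on the double-bonded chain carbon bound to the double-bonded ring carbon comes without a measured size.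

The compounds shown leave open whether the ring itself or the nature of the chain decides the outcome, since propyl is the only group without an aromatic ring, and a saturated ring such as cyclohexyl or a longer chain such as hexyl at this place would separate the two readings. Also open, going by these compounds, is whether a propyl chain ending in an amine or a carboxylic acid would stay at the limit or return to the range of the ring-bearing compounds.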